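An Ester Side Chain in Place of an Amide Side Chain

A few compounds are considered here, and "the series" means these few. Any claim that something is new, unique, unknown or untested is made for them only; others in the source may bear on it.

Measured so far in a functional assay with Oryctolagus cuniculus as the target; on this read-out lower numbers stand for stronger inhibition and higher numbers for weaker inhibition:
Compound 1 `COc1ccc(-c2nc(CNC(=O)c3cccnc3)sc2-c2ccc(OC)cc2)cc1` gives 25 nM.
Compound 2 `COc1ccc(-c2nc(C(=O)N3CCCCC3CCO)sc2-c2ccc(OC)cc2)cc1` gives 45 nM.
Compound 3 `CCOC(=O)C1=C(C)N=C(C)/C(=C(/O)OCC)C1c1nc(-c2ccc(OC)cc2)c(-c2ccc(OC)cc2)s1` gives < 100 nM, a limit of the assay rather than a number.

Compound 1 has the lowest of the two numbers, with compound 2 close by and the gap within the usual scatter, so neither can be called stronger. The third value is the limit of < 100 nM in this assay, at which 1 of the 3 values shown sits. Compound 4 `CCOC(=O)/C=C/c1nc(-c2ccc(OC)cc2)c(-c2ccc(OC)cc2)s1` is not yet measured. It differs from compound 1 in one place: 2-(ethoxycarbonyl)ethenyl in place of (((pyridin-3-yl)carbonyl)amino)methyl on an aromatic carbon. Among the measured compounds shown here, no measured pair shows this kind of change. Compound 1 at 25 nM and compound 2 at 45 nM carry different groups at that place and both give low numbers. On that basis the step is expected to be modest, toward a somewhat higher number, a 2.4-fold higher number from compound 1 to compound 4 (0.38 log units; beyond the scatter). For compound 4 the expected value is 60 nM, within 15 nM to 250 nM.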

Compound 4, half-maximal inhibitory concentration: 20 nM
The estimate for compound 4 lay 3.0-fold (0.48 log units) above the measured number; the measured number falls inside the stated range.
By their numbers in this assay, from the lowest: compounds 4, 1 and 2 (each within the scatter of the next, the first and the last beyond it).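

In this assay the swap to 2-(ethoxycarbonyl)ethenyl gives a 1.3-fold lower number from compound 1 to compound 4 (0.10 log units; within the scatter). This place, on an aromatic carbon next to the ring nitrogen and next to the ring sulfur, can therefore lose the six-membered aromatic ring and the hydrogen-bond donor of compound 1 and still give a low number. Nothing measured here explains this result.

Still open, going by these compounds, is whether the ethyl ester itself matters: a carboxylic acid or a primary amide at the end of the chain could answer that. A longer chain at this place also remains untested in the compounds shown.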